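Tert-butoxycarbonyl removal on the chain amine: compound 4

The source may hold more compounds than are shown below. What is called first, only, known or untested is meant among the compounds shown, and "the series" means these compounds.

Of the compounds shown here, three have been tested in a functional assay on MCF7 cells (Homo sapiens) for inhibition, read by MTT assay, with a stated time of 72 h; on this read-out higher numbers stand for weaker inhibition and lower numbers for stronger inhibition. Compound 1 `C[C@H](NC(=O)c1cc(Cl)ccc1OCCNC(=O)OC(C)(C)C)C(=O)Nc1ccc([N+](=O)[O-])cc1Cl` carries a tert-butoxycarbonyl group on the chain amine. In this assay compound 1 gives > 10000 nM, which is a limit of the assay and not a number. Compound 2 `C[C@H](NC(=O)c1cc(Cl)ccc1OCCN)C(=O)Nc1ccc([N+](=O)[O-])cc1Cl` differs from compound 1 by hydrogen in place of tert-butoxycarbonyl on an amine nitrogen. In this assay compound 2 gives > 10000 nM, again a limit. The step is therefore a step that the two limits leave unreadable from compound 1 to compound 2. Compound 3 `CC(C)(C)OC(=O)CC[C@H](NC(=O)c1cc(Cl)ccc1OCCNC(=O)OC(C)(C)C)C(=O)Nc1ccc([N+](=O)[O-])cc1Cl` differs from compound 1 in the core by (tert-butoxycarbonyl)methyl in place of hydrogen on a saturated chain carbon, two bonds along the chain from an amide-type nitrogen and a carbonyl carbon. In this assay compound 3 gives > 10000 nM, also a limit. The step from compound 1 to compound 3 is thus a step that the two limits leave unreadable from compound 1 to compound 3. Compound 4 `CC(C)(C)OC(=O)CC[C@H](NC(=O)c1cc(Cl)ccc1OCCN)C(=O)Nc1ccc([N+](=O)[O-])cc1Cl` is not yet measured; it differs from compound 3 by hydrogen in place of tert-butoxycarbonyl on an amine nitrogen, the same change as from compound 1 to compound 2, at the same place. Because (the limit of > 10000 nM in this assay, at which 3 of the 3 values shown sit), no readable inhibition has appeared anywhere in this set. The step is expected to be a step that the limit leaves unreadable from compound 3 to compound 4. Compound 4 is estimated at 20000 nM, with a range of 5000 nM to 80000 nM, and the assay is expected most likely to report only a limit again.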

Compound 4, half-maximal inhibitory concentration: 3080 nM
For compound 4 the middle estimate is 6.5-fold (0.81 log units) above the measured one, and the stated range ends above it.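

In this assay, for the compounds shown here, the free chain amine reads as an at least 3.2-fold lower number from compound 3 to compound 4 (0.51 log units; beyond the scatter), and the (tert-butoxycarbonyl)methyl group on the saturated chain carbon reads as an at least 3.2-fold lower number from compound 2 to compound 4 (0.51 log units; beyond the scatter), so compound 4 is the only compound here with a readable value. Compound 2 gives > 10000 nM, which is a limit of the assay and not a number. The same tert-butoxycarbonyl removal on the core of compound 1 is therefore unreadable, as are the other steps between two limits, so this shows that the change can matter on the core of compound 3 but not that it carries over from one core to another, or by how much: the limit of > 10000 nM in this assay, at which 3 of the 4 values shown sit.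

Still open, from the compounds shown here alone, is how a carboxylic acid in place of the tert-butyl ester on the side chain of compound 4 would read in this assay. Also open, going by these compounds, is whether a longer chain in place of 2-aminoethyl would keep a readable value on this core.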